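Fluoro to Methoxy: Expected Effect on Cell Growth

This account rests on a few compounds, and the source may have more. Where it says the series, first, only, none or still open, it means among the compounds named here.

Three compounds have so far been measured in a functional assay on A549 cells (Homo sapiens) for antiproliferative activity, read by sulforhodamine B assay, with a stated time of 72 h; on this read-out lower numbers stand for stronger inhibition and higher numbers for weaker inhibition:
Compound 1, `COc1ncc(-c2ccc3ncnc(Nc4ccc(OCCO)c(F)c4)c3c2)cc1NS(=O)(=O)c1ccc(F)cc1F`, gives 6640 nM.
Compound 2, `COc1ncc(-c2ccc3ncnc(Nc4ccc(OCCO)c(Cl)c4)c3c2)cc1NS(=O)(=O)c1ccc(F)cc1F`, gives 5980 nM.
Compound 3, `COc1ncc(-c2ccc3ncnc(Nc4cnn(CCCO)c4)c3c2)cc1NS(=O)(=O)c1ccc(F)cc1F`, gives 4830 nM.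

Compound 1 stands at the top of these three numbers, but nothing separates them beyond the scatter. Compound 4, `COc1cc(Nc2ncnc3ccc(-c4cnc(OC)c(NS(=O)(=O)c5ccc(F)cc5F)c4)cc23)ccc1OCCO`, has not yet been measured. It differs from compound 1 in one place: methoxy in place of fluoro on an aromatic carbon. Going by the values given here, two measured steps bear on this. The carbon in question is the same one that carried chloro instead of fluoro in the step of a 1.1-fold lower number from compound 1 to compound 2 (0.05 log units; within the scatter), a change too small to count. Exchanging the whole 3-fluoro-4-(2-hydroxyethoxy)phenyl group for a 1-(3-hydroxypropyl)-1H-pyrazol-4-yl group, in the step of a 1.4-fold lower number from compound 1 to compound 3 (0.14 log units; within the scatter), likewise stayed within the scatter. Since neither a different halogen at this carbon nor a wholly different group on that nitrogen shifted the number, a methoxy group at this carbon is expected to leave it essentially where it is, and the estimated step is a 1.1-fold lower number from compound 1 to compound 4 (0.04 log units; within the scatter), that is, none beyond the scatter. Compound 4 is accordingly expected to give about 6000 nM in this assay, with a likely range from 3000 nM to 12000 nM.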

Compound 4, half-maximal inhibitory concentration: 3760 nM
For compound 4 the middle estimate is 1.6-fold (0.20 log units) above the measured one, and the stated range covers the measured number.
By their numbers in this assay, from the lowest: compounds 4, 3, 2 and 1 (each within the scatter of the next).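

The carbon ortho to a 2-hydroxyethoxy group has now carried a substituent that is not a halogen. In this assay, going to methoxy, which brings one more heavy atom and a hydrogen-bond acceptor, stays within the scatter whether it replaces fluoro (a 1.8-fold lower number from compound 1 to compound 4 (0.25 log units; within the scatter)) or chloro (a 1.6-fold lower number from compound 2 to compound 4 (0.20 log units; within the scatter)), and exchanging the pyrazole-bearing side group for the 4-(2-hydroxyethoxy)-3-methoxyphenyl group also stays within it (a 1.3-fold lower number from compound 3 to compound 4 (0.11 log units; within the scatter)). So fluoro, chloro and methoxy at this carbon cannot be told apart here, and no measurement is available that could explain this result.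

As far as these compounds go, it remains open whether any group at this carbon can shift the number beyond the scatter, which a plain hydrogen, an amine or a carboxylic acid there could test, as could a longer chain in place of the 2-hydroxyethoxy group. The compounds shown also leave open whether this indifference would hold in any other assay, since all of them are compared on this single cell-growth read-out.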